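Fluorine position on the benzyl arm of the thiourea series

The compounds below may be only part of what the source reports. "The series", "measured", "known", "first", "only" and "open" are said of these compounds alone.

Working notes on the set around compound 2 `Nc1ccccc1NC(=O)c1ccc(NC(=S)NCc2cccc(F)c2)cc1`, which in a functional assay on HCT-116 cells (Homo sapiens) for cytotoxicity, read by MTT assay, with a stated time of 72 h (a higher number here means a weaker inhibitor, a lower number a stronger inhibitor), gives 5900 nM. Among the three measured compounds this is the lowest number, but every gap is within the scatter: compound 1 `Nc1ccccc1NC(=O)c1ccc(NC(=S)NCc2cncc(Br)c2)cc1` gives 9200 nM, and compound 3 `Nc1ccc(CNC(=O)Nc2ccc(C(=O)Nc3ccccc3N)cc2)cn1`, a urea rather than a thiourea with a different arm, gives 7300 nM. Within the data shown here, the one single-point step available, a 1.6-fold lower number from compound 1 to compound 2 (0.19 log units; within the scatter), does not leave the scatter either.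

Compound 4 `Nc1ccccc1NC(=O)c1ccc(NC(=S)NCc2ccccc2F)cc1` carries the same atoms as compound 2, joined differently: 2-fluorophenyl in place of 3-fluorophenyl on a saturated chain carbon bound to an amide-type nitrogen. Among the measured compounds shown here, no measured pair shows this exact change; the only step at the same place, a 1.6-fold lower number from compound 1 to compound 2 (0.19 log units; within the scatter), exchanges a different group and is itself within the scatter. On that basis, and with the whole series sitting close together in this assay, no step beyond the scatter is expected for compound 4, in either direction. The estimated step is a 1.0-fold higher number from compound 2 to compound 4 (0.01 log units; within the scatter). Compound 4 is therefore estimated at 6000 nM, with a range of 3000 nM to 12000 nM.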

Compound 4, half-maximal inhibitory concentration: 6300 nM
For compound 4 the middle estimate is 1.1-fold (0.02 log units) below the measured one, and the stated range covers the measured number.
By their numbers in this assay, from the lowest: compounds 2, 4, 3 and 1 (each within the scatter of the next).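

Among these compounds, exchanging 3-fluorophenyl for 2-fluorophenyl on a saturated chain carbon bound to an amide-type nitrogen is the first change in the set that moves only the fluorine, and in this assay it gives no step beyond the scatter (a 1.1-fold higher number from compound 2 to compound 4 (0.03 log units; within the scatter)). Replacing 5-bromopyridin-3-yl with 2-fluorophenyl also stays within the scatter (a 1.5-fold lower number from compound 1 to compound 4 (0.16 log units; within the scatter)), so all three arms on the thiourea now lie within the scatter of one another at this place. No measured evidence bears on this result.

Still open, on these data alone, is whether a longer chain at this place, or an amine or a carboxylic acid on the ring, would give a step beyond the scatter. The compounds shown also include no pair that differs only in urea against thiourea.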